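A Chlorine Added to the Central Ring of Compound 2

The source may report more compounds than this note shows. Statements on the series, on what has been measured and on what is new or still open speak of the compounds shown alone.

Compound 2 `Cc1cc2c(c(Oc3cccc(NS(=O)(=O)c4ccc(Cl)cc4)c3)n1)C(=O)N(C(C)C)C2=O` gives 13 nM in a functional assay on HEK293 cells for agonist activity at Glucose-dependent insulinotropic receptor (Homo sapiens), read by cAMP accumulation, with a stated time of 30 min; on this read-out higher numbers stand for an effect only at larger amounts of compound and lower numbers for an effect already at smaller amounts. Among the three measured compounds it stands second highest: compound 1 `CCN1C(=O)c2cc(C)nc(Oc3cccc(NS(=O)(=O)c4ccc(Cl)cc4)c3)c2C1=O` gives 11 nM, and the step of a 1.2-fold higher number from compound 1 to compound 2 (0.07 log units; within the scatter) lies within the scatter, while compound 3 `Cc1cc2c(c(Oc3cccc(NS(=O)(=O)c4ccc(Cl)cc4)c3)n1)C(=O)N(c1ccccc1)C2=O` gives 299 nM, with a large step of a 23-fold higher number from compound 2 to compound 3 (1.36 log units; beyond the scatter) and likewise a 27-fold higher number from compound 1 to compound 3 (1.43 log units; beyond the scatter). Compound 4 `Cc1cc2c(c(Oc3cc(NS(=O)(=O)c4ccc(Cl)cc4)ccc3Cl)n1)C(=O)N(C(C)C)C2=O` differs from compound 2 by chloro in place of hydrogen on an aromatic carbon. Every measured step alters only the group on the amide-type nitrogen in the ring, not the aromatic ring that receives the new chloro group, so none bears directly on this change, and no step beyond the scatter is expected. For compound 4 the estimate is 15 nM, within 5 nM to 50 nM, an expected step of a 1.2-fold higher number from compound 2 to compound 4 (0.06 log units; within the scatter).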

Compound 4, half-maximal effective concentration: 33 nM
Estimate against measurement, compound 4: 2.2-fold (0.34 log units) below; the range from low to high includes it.
By their numbers in this assay, from the lowest: compounds 1 and 2 (each within the scatter of the next); then compound 4; then compound 3.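

Among these compounds, earlier steps changed only the group on the amide-type nitrogen in the ring, so this is the first test of the aromatic carbon para to the ((4-chlorophenyl)sulfonyl)amino group. Chloro in place of hydrogen there gives a 2.5-fold higher number from compound 2 to compound 4 (0.40 log units; beyond the scatter) and so a modest loss beyond the scatter, which shows that this position responds, though less than the nitrogen does in a 23-fold higher number from compound 2 to compound 3 (1.36 log units; beyond the scatter). Nothing available explains this loss. From the compounds shown here alone, whether fluoro, methyl or methoxy at this carbon would fare better or worse remains open, as does whether chloro would have the same effect with ethyl on the nitrogen.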